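Swapping 2-chloroethyl for diethylamino

The source may report more compounds than this note shows. Statements on the series, on what has been measured and on what is new or still open speak of the compounds shown alone.

In a functional assay for inhibition, with Homo sapiens as the target (a lower number here means that less compound is needed, a higher number that more compound is needed for the effect), compound 1 `CCC(Cl)C(=O)Nc1ccc(C2=NNC(=O)CC2)cc1` gives 1.47 ug/mL. Compound 2 `O=C1CCC(c2ccc(NC(=O)CCCCl)cc2)=NN1` reaches only a limit of the assay, > 46.4 ug/mL. Compound 3 `CCN(CC)CC(=O)Nc1ccc(C2=NNC(=O)CC2)cc1` carries diethylamino in place of 2-chloroethyl on a saturated chain carbon bound to a carbonyl carbon, (diethylamino in place of 2-chloroethyl on a saturated chain carbon bound to a carbonyl carbon). Going by the values given here, the only measured step bearing on this, an at least 31-fold higher number from compound 1 to compound 2 (1.49 log units; beyond the scatter), is large and also lies in the group on a carbonyl carbon, so a sizeable shift is plausible, and from a limit it can only be read downward. A step to a lower number is expected, an at least 3.0-fold lower number from compound 2 to compound 3 (0.49 log units; beyond the scatter). Compound 3 is estimated at 15 ug/mL, within a range of 2.5 ug/mL to 60 ug/mL.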

Compound 3, half-maximal effective concentration: about 10 ug/mL
Compound 3: middle estimate off by 1.5-fold (0.18 log units), on the high side; low and high end bracket the measured number.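

In this assay, the chain on the carbonyl carbon does not have to stay at the assay's limit once diethylamino replaces 2-chloroethyl, with an at least 4.6-fold lower number from compound 2 to compound 3 (0.66 log units; beyond the scatter). Compound 2 gives a limit and not a number, so that step has only a lower bound: the limit of > 46.4 ug/mL in this assay, at which 1 of the 3 values shown sits. The change still does not recover the earlier level, with a 6.8-fold higher number from compound 1 to compound 3 (0.83 log units; beyond the scatter).

The compounds shown do not tell whether the nitrogen or the larger group matters here. On these data alone, it also stays open whether a ring amine such as piperidine, or a carboxylic acid on this chain, would come closer to compound 1.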